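Aryl exchange in a cytotoxicity series at the assay limit

A few compounds are considered here, and "the series" means these few. Any claim that something is new, unique, unknown or untested is made for them only; others in the source may bear on it.

In an ADME assay on HepG2 2.2.15 cells (Homo sapiens) for cytotoxicity, read by MTT assay, with stated times of 3 days and 7 days (on this read-out higher numbers stand for lower toxicity in this test and lower numbers for higher toxicity in this test), compound 1 `O=C(NCc1ccc(Cl)cc1)c1cc(-c2ccccc2)nc2ccccc12` gives > 20000 nM, which is a limit of the assay rather than a number. Compound 2 `O=C(c1cc(-c2cccc(Br)c2)nc2ccccc12)N1CCC(Cc2ccccc2)CC1` gives > 20000 nM in this assay, again a limit and not a number. Going by the values given here, compound 2 therefore stands at the limit of > 20000 nM in this assay, at which 2 of the 2 values shown sit, and nothing in the numbers so far separates it from compound 1. Compound 3 `CC(C)Cc1ccc(-c2cc(C(=O)N3CCC(Cc4ccccc4)CC3)c3ccccc3n2)cc1` differs from compound 2 by 4-isobutylphenyl in place of 3-bromophenyl on an aromatic carbon. Among the compounds with values here, no measured pair covers this kind of change, so the expectation rests on the two limits alone. No move beyond the usual scatter is expected, a number no higher from compound 2 to compound 3 (the limit leaves the size open). Compound 3 is accordingly expected to give 20000 nM in this assay, with a range from 6000 nM to 50000 nM, and it is thought most likely that the assay again reports only a limit for compound 3.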

Compound 3, half-maximal cytotoxic concentration: > 20000 nM
Compound 3: only a limit was reported; the forecaster's own chance of this, stated with the estimate: 70%; the middle value lies on the limit itself.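

No step can be read from compound 2 to compound 3 in this assay, because both values are limits and not numbers: the limit of > 20000 nM in this assay, at which 3 of the 3 values shown sit.

The compounds shown leave open whether any change to the shared core would give an actual number in this assay.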